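Compound 3 loses its fluoro: what to expect

This account rests on a few compounds, and the source may have more. Where it says the series, first, only, none or still open, it means among the compounds named here.

Three related compounds have been tested in a functional assay on MCF7 cells (Homo sapiens) for antiproliferative activity, read by MTT assay, with a stated time of 48 h; on this read-out higher numbers stand for weaker inhibition and lower numbers for stronger inhibition. In it compound 1 (`Oc1ccc2ccccc2c1C(Nc1nc2ccccc2s1)c1cn(-c2ccccc2)nc1-c1cccc(Cl)c1`) gives 20700 nM, compound 2 (`COc1ccc2nc(NC(c3cn(-c4ccccc4)nc3-c3ccc(F)cc3)c3c(O)ccc4ccccc34)sc2c1`) gives 16900 nM and compound 3 (`Oc1ccc2ccccc2c1C(Nc1nc2ccc(Cl)cc2s1)c1cn(-c2ccccc2)nc1-c1ccc(F)cc1`) gives 21600 nM. These three numbers lie within the usual scatter of one another, so they do not rank compound 3 against the other two.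

Compound 4 (`Oc1ccc2ccccc2c1C(Nc1nc2ccc(Cl)cc2s1)c1cn(-c2ccccc2)nc1-c1ccccc1`) has not been measured yet. It differs from compound 3 in one place: hydrogen in place of fluoro on an aromatic carbon. In words, hydrogen stands in place of fluoro on an aromatic carbon, which turns 4-fluorophenyl into phenyl.

Going by the values given here, only one measured step changes a single place, a 1.3-fold higher number from compound 2 to compound 3 (0.11 log units; within the scatter), and there chloro replaces methoxy on an aromatic carbon. That step stays within the scatter, but it involves other groups in another place, so it is only a loose guide. Among the compounds with values here, no measured step removes this fluoro. With that limited evidence, no step beyond the scatter is expected in this assay. The expected step is a 1.1-fold lower number from compound 3 to compound 4 (0.03 log units; within the scatter). For compound 4 the estimated value is 20000 nM, with an expected range from 11000 nM to 36000 nM.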

Compound 4, half-maximal inhibitory concentration: 36300 nM
Estimate against measurement, compound 4: 1.8-fold (0.26 log units) below, outside the stated range (above it).
By their numbers in this assay, from the lowest: compounds 2, 1, 3 and 4 (each within the scatter of the next, the first and the last beyond it).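

In this assay, going by these compounds alone, the swap of fluoro for hydrogen gives a 1.7-fold higher number from compound 3 to compound 4 (0.23 log units; within the scatter), the first direct reading at this place, on an aromatic carbon para to a large group. The step stays within the scatter, so the 4-fluorophenyl and phenyl forms of this chloro-bearing compound cannot be told apart here, and this single pair gives no sign that the fluoro matters for the read-out. The earlier step changed another place on the molecule and could say nothing about this one, while nothing measured here offers a reason for the present result.

The compounds shown cover only fluoro and hydrogen at this place, so it remains open whether a larger or very different group there, such as an amine, a carboxylic acid or a longer chain like butyl, would produce a step beyond the scatter. Going by these compounds, it is also open whether the same swap would stay as small with methoxy in place of chloro on the other side of the molecule, since this pair tests it with chloro alone.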